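The compounds below may be only part of what the source reports. "The series", "measured", "known", "first", "only" and "open" are said of these compounds alone.

Measured so far in a functional assay on MT4 cells (Homo sapiens) for inhibition; a higher number here means a weaker inhibitor, a lower number a stronger inhibitor:
Compound 1 `C=C1[C@H](n2cnc3c(N(C)C)nc(N)nc32)O[C@H](CO)[C@H]1O`: > 500000 nM
Compound 2 `C=C1[C@H](n2cnc3c(OC)nc(N)nc32)O[C@H](CO)[C@H]1O`: 180000 nM

Compound 1 reads > 500000 nM, which is a limit of the assay and not a number. Within the data shown here, that leaves compound 2, at 180000 nM, as the only true number in this assay so far. The next compound, compound 3 `C=C1[C@H](n2cnc3c(SC)nc(N)nc32)O[C@H](CO)[C@H]1O`, carries methylsulfanyl in place of methoxy on an aromatic carbon. Among the measured compounds shown here, only one measured step bears on this change: an at least 2.7-fold lower number from compound 1 to compound 2 (0.44 log units; beyond the scatter), with methoxy in place of dimethylamino on an aromatic carbon. It shows that the group at this carbon can move the number, but its size is only a bound, and it does not involve methylsulfanyl. It therefore sets neither a size nor a direction for the new exchange. The exchange swaps one group of two heavy atoms for another, so no step beyond the scatter is expected, and the estimate stays close to compound 2 at 180000 nM. The expected change is a 1.2-fold lower number from compound 2 to compound 3 (0.08 log units; within the scatter). For compound 3 the estimated value is 150000 nM, with an expected range from 50000 nM to 450000 nM.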

Compound 3, half-maximal inhibitory concentration: > 500000 nM
Compound 3 ended at the assay's limit; the forecaster's own chance of this, stated with the estimate: 25%; at least 3.3-fold (0.52 log units) between middle value and limit.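

In this assay, methylsulfanyl in place of methoxy on an aromatic carbon gives an at least 2.7-fold higher number from compound 2 to compound 3 (0.44 log units; beyond the scatter), so two groups with the same counts of heavy atoms, donors and acceptors do not read alike at this position. The value of compound 3, > 500000 nM, is a limit of the assay and not a number. The step to compound 3 is therefore only a bound, and the step between compound 1 and compound 3 cannot be read, because both of these compounds rest on the same limit: the limit of > 500000 nM in this assay, at which 2 of the 3 values shown sit.

Among the three groups shown, only methoxy gives a true number, and it remains open whether ethoxy, a primary amino group or chlorine at this carbon would read like compound 2, at 180000 nM, or would give a lower number. On these data alone, how far compound 1 and compound 3 lie beyond the limit, and whether they differ from each other, also remains open.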